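The source may hold more compounds than are shown below. What is called first, only, known or untested is meant among the compounds shown, and "the series" means these compounds.

Measured so far:
- compound 1 `CCOc1ccccc1C(=O)/C=C/c1ccccc1`: 609 nM
- compound 2 `CN(C)C(=O)c1ccccc1C(=O)/C=C/c1ccccc1`: 5500 nM
- compound 3 `O=C(/C=C/c1ccccc1)c1ccccc1Br`: 1660 nM

All three values come from a functional assay for inhibition, with Homo sapiens as the target; a lower number here means a stronger inhibitor, a higher number a weaker inhibitor. Compound 3 holds the middle place among these numbers, with compound 1 lower and compound 2 higher.

The next compound to be tested is compound 4 `O=C(/C=C/c1ccccc1)c1ccccc1NS(=O)(=O)C(F)(F)F`. It has ((trifluoromethyl)sulfonyl)amino in place of bromo on an aromatic carbon, ortho to a large group: ((trifluoromethyl)sulfonyl)amino in place of bromo on an aromatic carbon.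

Among the measured compounds shown here, none of the measured compounds carries this new group, so no measured step predicts the change directly. The nearest evidence comes from swaps among the ethoxy, dimethylcarbamoyl and bromo compounds. All three swaps were modest, and the largest was a 9.0-fold higher number from compound 1 to compound 2 (0.96 log units; beyond the scatter).

Compound 2 seems the closest match among these, and it points towards a higher number: a 3.3-fold lower number from compound 2 to compound 3 (0.52 log units; beyond the scatter). Compound 1 goes against that direction: a 2.7-fold higher number from compound 1 to compound 3 (0.44 log units; beyond the scatter). The direction is therefore only a leaning, and a wide range is needed.

In this assay, the expected change is a modest one: a 2.4-fold higher number from compound 3 to compound 4 (0.38 log units; beyond the scatter). The estimate for compound 4 is 4000 nM, with an expected range from 900 nM to 15000 nM.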

Compound 4, half-maximal inhibitory concentration: 5850 nM
Beside the measured number, compound 4's estimate is 1.5-fold (0.17 log units) below it, within the range that was stated.
By their numbers in this assay, from the lowest: compound 1; then compound 3; then compounds 2 and 4 (each within the scatter of the next).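

In this assay, putting ((trifluoromethyl)sulfonyl)amino on this aromatic carbon, ortho to a large group, gives a 3.5-fold higher number from compound 3 to compound 4 (0.55 log units; beyond the scatter) and also a 9.6-fold higher number from compound 1 to compound 4 (0.98 log units; beyond the scatter) for the swap from ethoxy, so the new group sits on the high side of both of these neighbours. Set against dimethylcarbamoyl, it gives a 1.1-fold higher number from compound 2 to compound 4 (0.03 log units; within the scatter) and the two groups cannot be told apart here, even though they differ in their atoms, which means that compound 1, with ethoxy, keeps the lowest number of the four. Nothing measured here explains why these groups read as they do.

The compounds shown place only ethoxy, dimethylcarbamoyl, bromo and ((trifluoromethyl)sulfonyl)amino on this carbon, so it remains open how a simple amine or a carboxylic acid would read there. From the compounds shown here alone, it is also open whether a longer chain than ethoxy, such as propoxy, would bring the number lower still or push it back towards the values of compound 2 and compound 4.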